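Taking the side chain off compound 1

The source may hold more compounds than are shown below. What is called first, only, known or untested is meant among the compounds shown, and "the series" means these compounds.

In a functional assay on HepG2 cells (Homo sapiens) for inhibition, read by MTT assay, with a stated time of 72 h (a lower number here means a stronger inhibitor, a higher number a weaker inhibitor), compound 1 `COc1cc(/C=C/C(=O)c2c(OC)cc(O)c(CC=C(C)C)c2O)ccc1O` gives 21700 nM, compound 2 `COc1ccc(/C=C/C(=O)c2c(OC)cc(O)c(CC=C(C)C)c2O)cc1OC` gives 13800 nM and compound 3 `COc1cc(O)c(CC=C(C)C)c(O)c1C(=O)/C=C/c1ccc(Cl)cc1` gives 10100 nM. Compound 1 therefore matches compound 2 within the scatter and stands apart only from compound 3.

Compound 4 `COc1cc(/C=C/C(=O)c2c(O)cc(O)cc2OC)ccc1O` differs from compound 1 in one place: hydrogen in place of 3-methylbut-2-en-1-yl on an aromatic carbon. The two measured steps are small: a 1.6-fold lower number from compound 1 to compound 2 (0.20 log units; within the scatter) and a 2.1-fold lower number from compound 1 to compound 3 (0.33 log units; beyond the scatter). Both change other parts of the molecule, and all three measured compounds keep the 3-methylbut-2-en-1-yl group, so they show only a typical step size here. With no direct evidence, a moderately higher number is expected, an estimated 1.6-fold higher number from compound 1 to compound 4 (0.21 log units; within the scatter). For compound 4, the estimated value is 35000 nM, with an expected range of 15000 nM to 90000 nM.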

Compound 4, half-maximal inhibitory concentration: > 50000 nM
Compound 4: a limit, no number; the forecaster's own chance of this, stated with the estimate: 15%; at least 1.4-fold (0.15 log units) between middle value and limit.
By their numbers in this assay, from the lowest: compounds 3, 2 and 1 (each within the scatter of the next, the first and the last beyond it). At a limit, above all of these: compound 4.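

Replacing the 3-methylbut-2-en-1-yl group with hydrogen gives an at least 2.3-fold higher number from compound 1 to compound 4 (0.36 log units; beyond the scatter) and so shows that this aromatic carbon matters, since the number rises when the side chain leaves. The earlier compounds shown here all keep this group and could not show that. From the compounds shown here alone, the result for compound 4 is a limit and not a number, so the full size of the step stays unknown: the limit of > 50000 nM in this assay, at which 1 of the 4 values shown sits.

Still open, going by these compounds, is whether a methyl group, a longer chain or an amine at this carbon would hold the number near that of compound 1.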